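This account rests on a few compounds, and the source may have more. Where it says the series, first, only, none or still open, it means among the compounds named here.

Among the compounds with values here, compound 1, `O=C(N[C@@H]1CCCC[C@H]1O)c1cnc(Oc2ccccc2)c(-c2ccc(Cl)cc2)c1`, is one of two compounds measured in an ADME assay (liver) for pharmacokinetics, with Liver microsome (Rattus norvegicus) as the target, read by LC-MS, using microsomes, tested at 2 uM; a higher number here means faster removal of the compound, a lower number slower removal. In this assay compound 1 gives 0.353 mL/min/kg, the higher of the two numbers. Compound 2, `O=C(N[C@@H]1CCCC[C@H]1O)c1cnc(OCC2CC2)c(-c2cc(C(F)(F)F)ccc2Cl)c1`, gives 0.059 mL/min/kg in this assay; it differs from compound 1 in more than one place, so the two values alone do not tell which part of the structure drives the gap. Compound 3, `O=C(N[C@@H]1CCCC[C@H]1O)c1cnc(CCC2CC2)c(-c2ccc(Cl)cc2)c1`, has not yet been measured. It arises from compound 1 by a single change, (2-cyclopropylethyl in place of phenoxy on an aromatic carbon), with a 2-cyclopropylethyl group in place of the phenoxy group on the shared core. Within the data shown here, no measured pair isolates this change, so there is no direct guide to its size. The step of a 1.2-fold lower number from compound 1 to compound 3 (0.07 log units; within the scatter) is expected to stay within the usual scatter, in no clear direction. Compound 3 is therefore estimated at 0.3 mL/min/kg in this assay, with a likely range from 0.1 mL/min/kg to 1 mL/min/kg.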

Compound 3, clearance: 1.5 mL/min/kg
The estimate for compound 3 lay 5.0-fold (0.70 log units) below the measured number; measured number outside the range, above it.
By their numbers in this assay, from the lowest: compound 2; then compound 1; then compound 3.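

Putting 2-cyclopropylethyl in place of phenoxy, on the aromatic carbon next to the ring nitrogen, gives a 4.2-fold higher number from compound 1 to compound 3 (0.63 log units; beyond the scatter) in this assay, a step beyond the usual scatter and towards faster removal. Within the data shown here, this is the first pair of compounds here that differs in one place only, so it shows that the group at this position can shift the number on its own, which the gap between the two earlier compounds could not show. Nothing measured here bears on why the number rises.

The change removes the oxygen and the six-membered aromatic ring together and brings in a three-membered ring, so the compounds shown do not separate the roles of these parts. As far as these compounds go, how an amine or a plain butyl chain at this position would read also remains open.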